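Fluoro to Chloro on the Benzyl Ring of Compound 3

The compounds below may be only part of what the source reports. "The series", "measured", "known", "first", "only" and "open" are said of these compounds alone.

compound 1 `O=C(NCc1cn(Cc2ccc(Cl)cc2)nn1)c1cn(-c2ccccc2)nc1-c1ccccc1`: 8700 nM
compound 2 `O=C(NCc1cn(Cc2ccc(Cl)cc2)nn1)c1cn(-c2ccccc2)nc1-c1ccc(Cl)cc1`: 410 nM
compound 3 `COc1ccc(-c2nn(-c3ccccc3)cc2C(=O)NCc2cn(Cc3ccc(F)cc3)nn2)cc1`: 24100 nM

In a functional assay on MIA PaCa-2 cells (Homo sapiens) for antiproliferative activity, read by sulforhodamine B assay, with a stated time of 48 h (a higher number here means a weaker inhibitor of growth, a lower number a stronger inhibitor of growth), compound 3 gives 24100 nM, the highest of the three numbers; compound 1 gives 8700 nM and compound 2 gives 410 nM, both beyond the scatter below it. Compound 4 `COc1ccc(-c2nn(-c3ccccc3)cc2C(=O)NCc2cn(Cc3ccc(Cl)cc3)nn2)cc1` differs from compound 3 by chloro in place of fluoro on an aromatic carbon. Going by the values given here, the only measured step, a 21-fold lower number from compound 1 to compound 2 (1.33 log units; beyond the scatter), concerns a different place, chloro in place of hydrogen on the phenyl attached to the core, and so does not bear directly on this change; no measured pair shows the benzyl halogen exchanged alone. A step within the scatter is therefore expected, a 1.6-fold lower number from compound 3 to compound 4 (0.21 log units; within the scatter). Compound 4 is estimated at 15000 nM, with a range from 5000 nM to 45000 nM.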

Compound 4, concentration for 50% growth inhibition: 26300 nM
Compound 4: middle estimate off by 1.8-fold (0.24 log units), on the low side; the measured number falls inside the stated range.
By their numbers in this assay, from the lowest: compound 2; then compound 1; then compounds 3 and 4 (each within the scatter of the next).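

The exchange of fluoro for chloro on the benzyl ring in this assay gives a 1.1-fold higher number from compound 3 to compound 4 (0.04 log units; within the scatter), so this position shows no response to this halogen swap with methoxy on the phenyl attached to the core. With 4-chlorobenzyl held constant, the same phenyl shows a 64-fold higher number from compound 2 to compound 4 (1.81 log units; beyond the scatter) and a 3.0-fold higher number from compound 1 to compound 4 (0.48 log units; beyond the scatter), placing methoxy there on the weak side of both chloro and hydrogen. Nothing available explains these steps. Still open, from the compounds shown here alone, is whether the benzyl halogen stays as silent with chloro on that phenyl, and whether an amine or a carboxylic acid in the halogen's place would move the number.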